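Methyl for Trifluoromethyl on Two Related Amide Cores

The compounds below may be only part of what the source reports. "The series", "measured", "known", "first", "only" and "open" are said of these compounds alone.

Of the compounds shown here, three have so far been measured in an assay on CHO cells for displacement of a labelled ligand from adenosine receptor A3 (Homo sapiens), read by scintillation counting, with a stated time of 3 h; a lower number here means a stronger inhibitor, a higher number a weaker inhibitor. Compound 2 `CC(C)n1cc2c(Cl)nc(NC(=O)c3ccc(C(F)(F)F)cc3)nc2n1` gives 10300 nM in this assay. Compound 1 `Cc1ccc(C(=O)Nc2nc(Cl)c3cn(C(C)C)nc3n2)cc1` gives > 100000 nM in this assay, and that value is a limit of the assay rather than a number, (the limit of > 100000 nM in this assay, at which 1 of the 3 values shown sits). The step from one to the other is an at least 9.7-fold higher number from compound 2 to compound 1 (0.98 log units; beyond the scatter), and the change behind it is methyl in place of trifluoromethyl on an aromatic carbon. Compound 3 `CCOC(=O)c1nc(NC(=O)c2ccc(C(F)(F)F)cc2)nc2nn(CC(C)(C)C)cc12` stands on a second core and gives 1300 nM in this assay, the lowest of the two numbers measured; the difference between the two cores is not broken down here.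

Compound 4 `CCOC(=O)c1nc(NC(=O)c2ccc(C)cc2)nc2nn(CC(C)(C)C)cc12` has not yet been measured in this assay. It differs from compound 3 by methyl in place of trifluoromethyl on an aromatic carbon, and the place where this happens reads the same, word for word, as in the change from compound 2 to compound 1, so it is the same change made on the second core. The expected step is a 15-fold higher number from compound 3 to compound 4 (1.19 log units; beyond the scatter), which rests on the measured at least 9.7-fold higher number from compound 2 to compound 1 (0.98 log units; beyond the scatter). Compound 4 is therefore estimated to give 20000 nM in this assay, with the expected range running from 5000 nM to 100000 nM. Whether the second core carries the change in the same way as the first is what the coming measurement will show.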

Compound 4, inhibition constant: 900 nM
For compound 4 the middle estimate is 22-fold (1.35 log units) above the measured one, and the stated range ends above it.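

In this assay the change from trifluoromethyl to methyl on the second core gives a 1.4-fold lower number from compound 3 to compound 4 (0.16 log units; within the scatter), so compounds 3 and 4 cannot be told apart by this read-out. The clear loss of binding seen on the first core therefore did not carry over to the second, and the size of the step depended on the core in this pair of cores: the same change on two cores in this assay, an at least 9.7-fold higher number (0.98 log units; beyond the scatter) from compound 2 to compound 1 and a 1.4-fold lower number (0.16 log units; within the scatter) from compound 3 to compound 4, at least 14-fold (1.14 log units) apart, beyond the scatter of two such steps. Within the data shown here, this does not show how the change behaves on any other core, since each core offers only one pair, and compound 1, at one end of the first pair, sits at a limit of the assay and not at a number, so the true size of the first step and of the gap between the two steps stays unknown.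

The two cores differ in more than one place, and no compound shown separates those places, so it remains open which part of the second core goes with the flat step. On these data alone, it also remains open whether a methoxy group or a nitrile in place of trifluoromethyl would follow the same core-dependent course, or whether a carboxylic acid in place of the ethyl ester would restore the step seen on the first core.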